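This account rests on a few compounds, and the source may have more. Where it says the series, first, only, none or still open, it means among the compounds named here.

In an ADME assay on Vero 76 cells (Chlorocebus sabaeus) for cytotoxicity, read by neutral red uptake (a lower number here means that less compound is tolerated, a higher number that more compound is tolerated), compound 1 `O[C@@H]1[C@H](O)[C@@H]2C[C@@H]2[C@H]1n1cnc2c(NCC(C3CC3)C3CC3)nc(Cl)nc21` gives 10000 nM and compound 3 `O[C@@H]1[C@H](O)[C@@H]2C[C@@H]2[C@H]1n1cnc2c(NC(C3CCC3)C3CCC3)nc(Cl)nc21` gives 17000 nM. Compound 2 `OC[C@@]12C[C@@H]1[C@@H](n1cnc3c(NCc4ccccc4)nc(Cl)nc31)[C@H](O)[C@@H]2O`, built on a different core, gives > 100000 nM, which is a limit of this assay and not a number. Compound 2 thus stands at the limit of > 100000 nM in this assay, at which 1 of the 3 values shown sits.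

Compound 4 `CC(C)(O)[C@@H](Nc1nc(Cl)nc2c1ncn2[C@H]1[C@H](O)[C@H](O)[C@]2(CO)C[C@H]12)C1CC1` keeps the core of compound 2 and changes one group: 1-cyclopropyl-2-hydroxy-2-methylpropyl in place of benzyl on a nitrogen on an aromatic ring, (1-cyclopropyl-2-hydroxy-2-methylpropyl in place of benzyl on a nitrogen on an aromatic ring). Within the data shown here, only one measured step bears on a swap at this place, and only loosely, since it sits on the other core. Putting dicyclobutylmethyl in place of 2,2-dicyclopropylethyl gave a 1.7-fold higher number from compound 1 to compound 3 (0.23 log units; within the scatter). On that single step, no change beyond the scatter is expected from this swap, though a limit as the starting point leaves the size uncertain. The estimated step is an at least 1.2-fold lower number from compound 2 to compound 4 (0.09 log units; that floor lies within the scatter). For compound 4 the estimated value is 80000 nM, with an expected range of 30000 nM to 100000 nM. A limit may again be all that this assay reports.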

Compound 4, half-maximal cytotoxic concentration: > 100000 nM
Compound 4 gave a limit, no number (the forecaster's own chance of this, stated with the estimate: 60%); middle value at least 1.2-fold (0.09 log units) from the limit.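

In this assay compound 2 and compound 4 each give only a limit, so no step can be read between them: the limit of > 100000 nM in this assay, at which 2 of the 4 values shown sit.

The compounds shown leave open how far 1-cyclopropyl-2-hydroxy-2-methylpropyl in place of benzyl moves this read-out on the core of compound 2.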